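The compounds below may be only part of what the source reports. "The series", "measured", "known", "first", "only" and "open" are said of these compounds alone.

Compound 1 `O=C(NCc1ccccc1)c1cccn1-c1ccc2c(c1)B(O)OC2` and compound 2 `O=C(c1ccc(Cl)cc1)c1ccn(-c2ccc3c(c2)B(O)OC3)c1` share a common core. In an ADME assay on L929 cells (Mus musculus) for cytotoxicity, read by resazurin assay, with a stated time of 72 h (on this read-out higher numbers stand for weaker inhibition and lower numbers for stronger inhibition), compound 1 reaches only the limit of the assay, > 10 ug/mL. In this assay compound 2 likewise gives only a limit, > 10 ug/mL. Compound 2 therefore stands at the limit of > 10 ug/mL in this assay, at which 2 of the 2 values shown sit, with no number of its own. Compound 3 `CCCCCC(=O)c1ccn(-c2ccc3c(c2)B(O)OC3)c1` differs from compound 2 by pentyl in place of 4-chlorophenyl on a carbonyl carbon. Within the data shown here, no measured step of this kind is available. The step from compound 2 to compound 3 is expected to be none beyond the scatter, a step that the limit leaves unreadable from compound 2 to compound 3. Compound 3 is expected at 15 ug/mL, within 6 ug/mL to 40 ug/mL, most likely reported again as a limit.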

Compound 3, half-maximal inhibitory concentration: > 10 ug/mL
Compound 3 was reported as a limit; the forecaster's own chance of this, stated with the estimate: 75%; the middle value lies beyond the limit too.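

No step can be read from compound 2 to compound 3, as both give only a limit: the limit of > 10 ug/mL in this assay, at which 3 of the 3 values shown sit. Left open is whether pentyl in place of 4-chlorophenyl on a carbonyl carbon changes the read-out at all.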